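Swapping the triazole aryl group on a shared core

A few compounds are considered here, and "the series" means these few. Any claim that something is new, unique, unknown or untested is made for them only; others in the source may bear on it.

Three compounds share the same core and differ only at one point. Compound 1 `C=C1C(=O)[C@]23C[C@@]1(O)CC[C@H]2c1ccc(OS(=O)(=O)c2ccc(C)cc2)c(C)c1[C@@H]3Cn1cc(-c2ccccn2)nn1` carries a (4-methylphenyl)sulfonyl on the phenol oxygen and a pyridin-2-yl on the triazole; in a functional assay on A549 cells (Homo sapiens) for cytotoxicity, read by MTT assay, with a stated time of 4 days (on this read-out higher numbers stand for weaker inhibition and lower numbers for stronger inhibition), compound 1 gives 2310 nM. Compound 2 `C=C1C(=O)[C@]23C[C@@]1(O)CC[C@H]2c1ccc(O)c(C)c1[C@@H]3Cn1cc(-c2ccccc2)nn1` has a free phenol and a phenyl on the triazole, and in this assay compound 2 gives 1160 nM. Compound 3 `C=C1C(=O)[C@]23C[C@@]1(O)CC[C@H]2c1ccc(O)c(C)c1[C@@H]3Cn1cc(-c2ccccn2)nn1` keeps the free phenol with a pyridin-2-yl, and in this assay compound 3 gives 1570 nM. All three numbers lie within the scatter of one another: a 1.5-fold lower number from compound 1 to compound 3 (0.17 log units; within the scatter) and a 1.4-fold higher number from compound 2 to compound 3 (0.13 log units; within the scatter), so compound 3 cannot be placed apart from either.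

Compound 4 `C=C1C(=O)[C@]23C[C@@]1(O)CC[C@H]2c1ccc(O)c(C)c1[C@@H]3Cn1cc(-c2ccc(F)cc2)nn1` differs from compound 3 in one place: 4-fluorophenyl in place of pyridin-2-yl on an aromatic carbon. Going by the values given here, the step that bears on this is the one from compound 2 to compound 3, where the same position changed between phenyl and pyridin-2-yl with no shift beyond the scatter. A similar carbon-only ring now returns, so no shift beyond the scatter is expected, a 1.2-fold lower number from compound 3 to compound 4 (0.08 log units; within the scatter). Compound 4 is therefore estimated at 1300 nM, within 600 nM to 2800 nM.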

Compound 4, half-maximal inhibitory concentration: 940 nM
Compound 4: middle estimate off by 1.4-fold (0.14 log units), on the high side; the range from low to high includes it.
By their numbers in this assay, from the lowest: compounds 4, 2, 3 and 1 (each within the scatter of the next, the first and the last beyond it).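

In this assay, this carbon of the five-membered aromatic ring with 3 nitrogen accepts a 4-fluorophenyl in place of pyridin-2-yl, which removes the one hydrogen-bond acceptor counted in that group, and the result is a 1.7-fold lower number from compound 3 to compound 4 (0.22 log units; within the scatter). Fluoro in place of hydrogen on the phenyl ring gives a 1.2-fold lower number from compound 2 to compound 4 (0.09 log units; within the scatter), so with the free phenol kept, phenyl, pyridin-2-yl and 4-fluorophenyl cannot be told apart in this assay. No measurement shown here offers a reason why these three groups read alike.

On these data alone, all three are six-membered aromatic rings, so it remains open whether a group of another kind at this carbon, such as an aminomethyl group, a carboxylic acid or a longer alkyl chain, would move the number beyond the scatter. The same question stands for a cyclohexyl ring, which keeps the ring size but is not aromatic.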